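Compound 3: Expected Clearance After an Isomeric Ring Swap

The source may report more compounds than this note shows. Statements on the series, on what has been measured and on what is new or still open speak of the compounds shown alone.

Compound 1 `Cc1ccc(-c2ccc(Cl)c(C(=O)NCC3(O)CCCCCC3)c2)nn1` — 23 mL/min/kg
Compound 2 `O=C(NCC1(O)CCCC(F)(F)C1)c1cc(-c2ncc(F)cn2)ccc1Cl` — 10 mL/min/kg

In an in vitro ADME assay on microsomes from liver (Homo sapiens) for metabolic stability (a higher number here means faster removal of the compound, a lower number slower removal), compound 1 gives 23 mL/min/kg, the highest of the two numbers; compound 2 gives 10 mL/min/kg, and the gap between them is beyond the scatter. Compound 3 `Cc1cnc(-c2ccc(Cl)c(C(=O)NCC3(O)CCCCCC3)c2)nc1` differs from compound 1 by 5-methylpyrimidin-2-yl in place of 6-methylpyridazin-3-yl on an aromatic carbon. For the measured compounds named here, no measured pair shows this particular change, so no step for it in this assay is known; the expected step is one of either sign within the scatter, a 1.2-fold lower number from compound 1 to compound 3 (0.06 log units; within the scatter). For compound 3, the estimated value in this assay is 20 mL/min/kg, with a range from 10 mL/min/kg to 40 mL/min/kg.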

Compound 3, clearance: 53 mL/min/kg
Estimate against measurement, compound 3: 2.7-fold (0.42 log units) below, outside the stated range (above it).
By their numbers in this assay, from the lowest: compound 2; then compound 1; then compound 3.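

At this position, on an aromatic carbon para to a chloro group, the arrangement of the ring atoms alone moves the result in this assay: 5-methylpyrimidin-2-yl in place of 6-methylpyridazin-3-yl gives a 2.3-fold higher number from compound 1 to compound 3 (0.36 log units; beyond the scatter). The two groups match in heavy atoms, hydrogen-bond donors and acceptors, so those counts do not separate them here. No measurement shown accounts for this step.

The compounds shown leave open how a methoxy group or an amine in place of the methyl on the 5-methylpyrimidin-2-yl group would read in this assay. They also leave open whether this swap gives a similar step on another amide side chain.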